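The source may hold more compounds than are shown below. What is called first, only, known or untested is meant among the compounds shown, and "the series" means these compounds.

Measured so far:
compound 1 `CCCCNc1c(C#N)c(NCCCC)c2c(N)nc(N)nc2c1Cl` gives 0.6 ug/mL
compound 2 `CCCCNc1c(C#N)c(NCCCC)c2c(N)nc(N)nc2c1F` gives 1.6 ug/mL
compound 3 `N#Cc1c(NCc2ccccc2)c(Cl)c2nc(N)nc(N)c2c1NCc1ccccc1` gives 3.7 ug/mL

All three were tested in a functional assay on SK-OV-3 cells (Homo sapiens) for cytotoxicity, read by MTT assay; on this read-out higher numbers stand for weaker inhibition and lower numbers for stronger inhibition. Compound 1 and compound 2 share one core and differ in a single place: fluoro in place of chloro on an aromatic carbon. That change produced a 2.7-fold higher number from compound 1 to compound 2 (0.43 log units; beyond the scatter), so compound 2 inhibits the cells less strongly. Compound 3 is built on a different core, and the difference between the two cores is not broken down here. Its number is higher than that of compound 2 and higher still than that of compound 1, both gaps lying beyond the usual scatter.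

Compound 4 `N#Cc1c(NCc2ccccc2)c(F)c2nc(N)nc(N)c2c1NCc1ccccc1` has not been measured. It stands to compound 3 as compound 2 stands to compound 1: fluoro in place of chloro on an aromatic carbon. This is the same kind of change rather than the same one. Around the place compound 1 carries a butylamino group ortho and a butylamino group para, whereas compound 3 carries a benzylamino group ortho and a benzylamino group para.

Within the data shown here, because the only measured example of this swap is a 2.7-fold higher number from compound 1 to compound 2 (0.43 log units; beyond the scatter), a step of similar size is expected here. In this assay the expected step is a 2.4-fold higher number from compound 3 to compound 4 (0.39 log units; beyond the scatter). Compound 4 is therefore estimated at 9 ug/mL, most likely between 4 ug/mL and 20 ug/mL.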

Compound 4, half-maximal inhibitory concentration: 2.5 ug/mL
Compound 4: the middle estimate sits 3.6-fold (0.56 log units) above what was measured; measured number outside the range, below it.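

In this assay, putting fluoro in place of chloro on the core of compound 3 gives a 1.5-fold lower number from compound 3 to compound 4 (0.17 log units; within the scatter), so on this core the swap has no effect that can be told apart from the ordinary spread of repeated measurements. The swap therefore does not carry over with the same size from one core to the other, as the two steps set side by side show: the same change on two cores in this assay, a 2.7-fold higher number (0.43 log units; beyond the scatter) from compound 1 to compound 2 and a 1.5-fold lower number (0.17 log units; within the scatter) from compound 3 to compound 4, 3.9-fold (0.60 log units) apart, beyond the scatter of two such steps. The two pairs differ in carrying butylamino groups or benzylamino groups around the swapped place, but the data do not show why the steps differ, and two pairs are too few to give a rule for the series.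

The compounds shown leave open how a bromo or a methoxy group at this place would compare with chloro and fluoro on either core. They also leave open how the swap would behave with a longer chain, such as a hexylamino group, in place of the butylamino groups.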